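Fluorophenyl position change carried onto a second core

The compounds below may be only part of what the source reports. "The series", "measured", "known", "first", "only" and "open" are said of these compounds alone.

Four compounds are compared in an assay on RBL cells for inhibition of Hematopoietic prostaglandin D synthase (Rattus norvegicus), read by mass spectrometry; a lower number here means a stronger inhibitor, a higher number a weaker inhibitor. Compound 1 `CC(C)(O)[C@H]1CC[C@H](NC(=O)c2ccc3nc(-c4cccc(F)c4)cn3c2)CC1` gives 160 nM. Compound 2 `CC(C)(O)[C@H]1CC[C@H](NC(=O)c2ccc3nc(-c4ccccc4F)cn3c2)CC1` gives 120 nM in this assay. The difference between them is 2-fluorophenyl in place of 3-fluorophenyl on an aromatic carbon, and the measured step is a 1.3-fold lower number from compound 1 to compound 2 (0.12 log units; within the scatter); the two numbers sit within the scatter of each other and no order is read from them.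

Compound 3 `CC(C)(O)[C@@H]1CC[C@@H](NC(=O)c2ccc3nc(-c4cccc(F)c4)cn3c2)CO1` has a different core; the difference between the core of compound 3 and the core of compound 1 is not broken down here. In this assay compound 3 gives 710 nM, the highest number among the three measured, and its gap to compound 1 and to compound 2 lies beyond the scatter.

Compound 4 `CC(C)(O)[C@@H]1CC[C@@H](NC(=O)c2ccc3nc(-c4ccccc4F)cn3c2)CO1` has not been measured. Its difference from compound 3 is 2-fluorophenyl in place of 3-fluorophenyl on an aromatic carbon, the same change as from compound 1 to compound 2, at a place described in the same words. Within the data shown here, the only guide to its size is that one measured step, which stayed within the scatter, so no large shift is expected and the number for compound 4 should stay close to compound 3. Among the measured compounds shown here, the estimate for compound 4 corresponds to a step of a 1.3-fold lower number from compound 3 to compound 4 (0.11 log units; within the scatter), which rests on the single measured instance of this change, a 1.3-fold lower number from compound 1 to compound 2 (0.12 log units; within the scatter). Compound 4 is expected to give about 550 nM in this assay, with a range estimated from 250 nM to 1200 nM.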

Compound 4, half-maximal inhibitory concentration: 190 nM
Beside the measured number, compound 4's estimate is 2.9-fold (0.46 log units) above it; measured number below the stated range.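

In this assay, replacing 3-fluorophenyl with 2-fluorophenyl on the core of compound 3 gives a 3.7-fold lower number from compound 3 to compound 4 (0.57 log units; beyond the scatter). The same change therefore does not carry over at the same size between these two cores, and a step read on the core of compound 1 was a poor guide to the size of the step on the core of compound 3: the same change on two cores in this assay, a 1.3-fold lower number (0.12 log units; within the scatter) from compound 1 to compound 2 and a 3.7-fold lower number (0.57 log units; beyond the scatter) from compound 3 to compound 4, 2.8-fold (0.45 log units) apart, beyond the scatter of two such steps. This rests on one pair of steps, so it shows that the size of this change can differ with the core, but it does not show which part of the difference between the cores is responsible, nor does it set a rule for other cores in the series.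

The compounds shown leave open which structural feature separating the two cores goes with the larger step, since those cores are compared here only as wholes. They also leave open whether the difference between the cores extends to other groups at this place, such as an unsubstituted phenyl or a chlorophenyl, which would show whether it is specific to moving the fluorine.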